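This account rests on a few compounds, and the source may have more. Where it says the series, first, only, none or still open, it means among the compounds named here.

Compound 1 `Fc1ccc(-c2nc3cnc(Nc4ccc(C(F)(F)F)cn4)cc3[nH]2)cc1F`: 6000 nM. Compound 2 `Fc1ccc(Nc2cc3[nH]c(-c4ccc(F)c(F)c4)nc3cn2)nc1`: 42000 nM.

Among the measured compounds shown here, in a physicochemical assay for solubility, using the shake flask method, measured as kinetic solubility, with a stated time of 20 h, at pH 2 (on this read-out lower numbers stand for lower solubility and higher numbers for higher solubility), compound 2 holds the higher of the two numbers, the only measured step being a 7.0-fold higher number from compound 1 to compound 2 (0.85 log units; beyond the scatter). Compound 3 `O=C(O)c1ccc(Nc2cc3[nH]c(-c4ccc(F)c(F)c4)nc3cn2)nc1` differs from compound 2 by carboxy in place of fluoro on an aromatic carbon. For the measured compounds named here, no measured step exchanges a fluoro for a carboxy group, so the single step from compound 1 to compound 2 bears on it only loosely, and it gives no guide to direction. The step from compound 2 to compound 3 is therefore expected to stay within the scatter, a 1.4-fold lower number from compound 2 to compound 3 (0.15 log units; within the scatter). Compound 3 is estimated at 30000 nM, with a range from 6000 nM to 150000 nM.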

Compound 3, solubility: 11000 nM
Estimate against measurement, compound 3: 2.7-fold (0.44 log units) above; the measured number falls inside the stated range.
By their numbers in this assay, from the lowest: compounds 1 and 3 (each within the scatter of the next); then compound 2.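

In this assay, the position para to a large group now holds a third group, and carboxy in place of fluoro gives a 3.8-fold lower number from compound 2 to compound 3 (0.58 log units; beyond the scatter) in a step beyond the scatter. Carboxy in place of trifluoromethyl gives a 1.8-fold higher number from compound 1 to compound 3 (0.26 log units; within the scatter) and stays within the scatter, so only compound 2 stands apart among the three. Nothing at hand accounts for these steps.
Still open, going by these compounds, is whether an amine or a nitrile at this position would read like compound 2 or like compounds 1 and 3.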